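Methoxy addition on a bis-indole acrylonitrile series

The source may hold more compounds than are shown below. What is called first, only, known or untested is meant among the compounds shown, and "the series" means these compounds.

Compound 1 `COc1ccc2[nH]cc(/C=C(\C#N)C(=O)c3c[nH]c4ccccc34)c2c1` gives 21200 nM in a functional assay on MIA PaCa-2 cells (Homo sapiens) for cytotoxicity, read by WST assay, with a stated time of 24 h; a lower number here means a stronger inhibitor, a higher number a weaker inhibitor. Compound 2 `COc1ccc2[nH]cc(/C=C(\C#N)C(=O)c3c[nH]c4ccc(OC)cc34)c2c1`, which carries methoxy in place of hydrogen on an aromatic carbon, gives 28500 nM in this assay; the step of a 1.3-fold higher number from compound 1 to compound 2 (0.13 log units; within the scatter). Compound 3 `N#C/C(=C\c1c[nH]c2cc(F)ccc12)C(=O)c1c[nH]c2ccccc12` gives 23500 nM in this assay; the difference between the core of compound 3 and that of compound 1 is not broken down here. Compound 4 `COc1ccc2[nH]cc(C(=O)/C(C#N)=C/c3c[nH]c4cc(F)ccc34)c2c1` is not yet measured; relative to compound 3 it carries methoxy in place of hydrogen on an aromatic carbon, the same change as that from compound 1 to compound 2. Because a 1.3-fold higher number from compound 1 to compound 2 (0.13 log units; within the scatter) stayed within the scatter, a step of similar size is expected from compound 3 to compound 4, namely a 1.2-fold higher number from compound 3 to compound 4 (0.08 log units; within the scatter). Compound 4 is therefore estimated at 28000 nM in this assay, with an expected range from 14000 nM to 56000 nM.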

Compound 4, half-maximal inhibitory concentration: > 50000 nM
Compound 4: only a limit was reported (the forecaster's own chance of this, stated with the estimate: 10%); at least 1.7-fold (0.25 log units) between middle value and limit.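

The methoxy change, carried to a second core, gives an at least 2.1-fold higher number from compound 3 to compound 4 (0.32 log units; beyond the scatter) in this assay. For compound 4, the reported > 50000 nM is a limit of the assay and not a number. The two steps therefore show neither that the change carries over unchanged from one core to the other nor that it behaves differently on the two cores: the same change on two cores in this assay, a 1.3-fold higher number (0.13 log units; within the scatter) from compound 1 to compound 2 and an at least 2.1-fold higher number (0.32 log units; beyond the scatter) from compound 3 to compound 4; the limit leaves it open whether they differ

The compounds shown leave open how an amine, a carboxylic acid or a longer chain in place of methoxy would read in this assay. Also open, as far as these compounds go, is how the methoxy change would read on any core beyond these two.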